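Swapping the Aryl Group on a Shared Core

The source may hold more compounds than are shown below. What is called first, only, known or untested is meant among the compounds shown, and "the series" means these compounds.

Of the compounds shown here, two of a shared core have been measured in an assay on HEK293 cells for activation of Kir3.1/Kir3.2 (Homo sapiens), read by thallium flux; on this read-out higher numbers stand for an effect only at larger amounts of compound and lower numbers for an effect already at smaller amounts. Compound 1 `O=C(Cn1nnc(-c2ccccc2)n1)Nc1cc(C2CC2)nn1C1CCCCC1` gives 271 nM. Compound 2 `Cc1cc(NC(=O)Cn2nnc(-c3ccc(F)cc3)n2)n(C2CCCCC2)n1` gives 180 nM. The two numbers lie within the scatter of one another, so on the data shown compound 2 is not set apart from compound 1, and no step between the two is recorded.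

Compound 3 `COc1cccc(-c2nnn(CC(=O)Nc3cc(C)nn3C3CCCCC3)n2)c1` has not yet been measured. It differs from compound 2 in one place: 3-methoxyphenyl in place of 4-fluorophenyl on an aromatic carbon. Going by the values given here, with only two compounds measured, and those two inseparable, there is nothing in the data to suggest that a change in this part of the molecule moves the read-out. The step from compound 2 to compound 3 is therefore expected to be small, likely none beyond the scatter, in either direction: a 1.4-fold higher number from compound 2 to compound 3 (0.14 log units; within the scatter). Compound 3 is estimated at 250 nM, within a range from 80 nM to 800 nM.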

Compound 3, half-maximal effective concentration: 117 nM
Compound 3: middle estimate off by 2.1-fold (0.33 log units), on the high side; the measured number falls inside the stated range.
By their numbers in this assay, from the lowest: compounds 3, 2 and 1 (each within the scatter of the next, the first and the last beyond it).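

At this aromatic carbon of the shared core, 3-methoxyphenyl in place of 4-fluorophenyl gives a 1.5-fold lower number from compound 2 to compound 3 (0.19 log units; within the scatter) in this assay, the first step recorded at this position. The entering group counts one hydrogen-bond acceptor where the leaving group counts none, yet this exchange of aryl groups produces no step beyond the scatter, so the position accepts both groups with the read-out staying in the same range. Nothing measured here connects the outcome to any particular feature of either group.

The compounds shown leave open whether replacing the aryl group at this carbon with an amine, a carboxylic acid or a longer chain would produce a step beyond the scatter. They also leave open whether any aryl group without a methoxy or fluoro substituent would read the same way.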